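The compounds below may be only part of what the source reports. "The series", "measured", "known", "first", "only" and "open" are said of these compounds alone.

Working notes on the series. The three measured compounds share one core and differ only in the aryl group on a saturated chain carbon, two bonds along the chain from a double-bonded chain carbon. Compound 1 `C=C/C=C\[C@H](C)[C@H](OC(N)=O)[C@@H](C)[C@H](O)[C@@H](C)C/C(C)=C\[C@H](C)[C@@H](O)[C@@H](C)/C=C\CCc1cccc(O)c1` carries 3-hydroxyphenyl there; in a functional assay on A549 cells (Homo sapiens) for cytotoxicity (a higher number here means a weaker inhibitor, a lower number a stronger inhibitor), compound 1 gives 190 nM. Compound 2 `C=C/C=C\[C@H](C)[C@H](OC(N)=O)[C@@H](C)[C@H](O)[C@@H](C)C/C(C)=C\[C@H](C)[C@@H](O)[C@@H](C)/C=C\CCc1ccsc1` carries thiophen-3-yl; in this assay compound 2 gives 4000 nM, the step being a 21-fold higher number from compound 1 to compound 2 (1.32 log units; beyond the scatter). Compound 3 `C=C/C=C\[C@H](C)[C@H](OC(N)=O)[C@@H](C)[C@H](O)[C@@H](C)C/C(C)=C\[C@H](C)[C@@H](O)[C@@H](C)/C=C\CCc1cccc(O)c1C` carries 3-hydroxy-2-methylphenyl; in this assay compound 3 gives 910 nM, the second highest of the three numbers, reached by a 4.8-fold higher number from compound 1 to compound 3 (0.68 log units; beyond the scatter) and by a 4.4-fold lower number from compound 2 to compound 3 (0.64 log units; beyond the scatter).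

Compound 4 `C=C/C=C\[C@H](C)[C@H](OC(N)=O)[C@@H](C)[C@H](O)[C@@H](C)C/C(C)=C\[C@H](C)[C@@H](O)[C@@H](C)/C=C\CCc1ccc(C)c(O)c1` is the next step, with 3-hydroxy-4-methylphenyl in place of 3-hydroxy-2-methylphenyl on a saturated chain carbon, two bonds along the chain from a double-bonded chain carbon. The same atoms are kept and only the methyl changes place on the ring. Among the measured compounds shown here, no measured step covers such a move directly. For the measured compounds named here, two steps bear on it: a 4.8-fold higher number from compound 1 to compound 3 (0.68 log units; beyond the scatter) shows what one methyl on the ring cost, and a 4.4-fold lower number from compound 2 to compound 3 (0.64 log units; beyond the scatter) shows that the hydroxyphenyl is worth more than thiophen-3-yl. The methyl at the new place may cost as much as in compound 3, or less. The step of a 1.5-fold lower number from compound 3 to compound 4 (0.18 log units; within the scatter) is therefore expected to be small, if anything toward a lower number. Compound 4 is expected to give 600 nM in this assay, within 200 nM to 1800 nM.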

Compound 4, half-maximal inhibitory concentration: 4000 nM
Beside the measured number, compound 4's estimate is 6.7-fold (0.82 log units) below it, and the stated range ends below it.
By their numbers in this assay, from the lowest: compound 1; then compound 3; then compounds 2 and 4 (each within the scatter of the next).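

Moving the methyl on the ring is not a neutral change at this place: 3-hydroxy-4-methylphenyl in place of 3-hydroxy-2-methylphenyl gives a 4.4-fold higher number from compound 3 to compound 4 (0.64 log units; beyond the scatter) in this assay, although the two groups hold the same atoms. The cost of adding a methyl to the 3-hydroxyphenyl of compound 1 therefore depends on where the methyl stands, with a 21-fold higher number from compound 1 to compound 4 (1.32 log units; beyond the scatter) set against a 4.8-fold higher number from compound 1 to compound 3 (0.68 log units; beyond the scatter), and the hydroxyphenyl is not worth more than thiophen-3-yl in every case: a 4.4-fold lower number from compound 2 to compound 3 (0.64 log units; beyond the scatter) is not repeated, as the step to the isomer reads no change at the digits printed from compound 2 to compound 4 (within the scatter). Nothing available on these compounds accounts for the difference between the two methyl placements.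

From the compounds shown here alone, what stays open is how much the hydroxyl itself contributes, which a methoxy or an amine in its stead on the ring of compound 1 would test. Also open, going by these compounds, is whether an ethyl or a chloro group in place of the methyl would follow the same course in compound 3 and compound 4.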